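The source may report more compounds than this note shows. Statements on the series, on what has been measured and on what is new or still open speak of the compounds shown alone.

In a functional assay on HT-1080 cells (Homo sapiens) for cytotoxicity, read by MTT assay, with a stated time of 72 h (on this read-out higher numbers stand for weaker inhibition and lower numbers for stronger inhibition), compound 2 `COc1ccc(/C=C2\CCC/C(=C\c3cccc(Br)c3)C2=O)cc1OC` gives 5200 nM, the highest number among the three measured compounds. Going by the values given here, compound 1 `COc1cccc(/C=C2\CCC/C(=C\c3cc(OC)c(OC)c(OC)c3)C2=O)c1OC` gives 2300 nM and compound 3 `COc1ccc(/C=C2\CCC/C(=C\c3cc(OC)c(OC)c(OC)c3)C2=O)cc1OC` gives 1100 nM; the step of a 2.1-fold lower number from compound 1 to compound 3 (0.32 log units; beyond the scatter) is the only single-point change on record, and it concerns a different replacement at the same place. Compound 4 `COc1cc(/C=C2\CCC/C(=C\c3ccc(OC)c(OC)c3)C2=O)ccc1O` differs from compound 2 by 4-hydroxy-3-methoxyphenyl in place of 3-bromophenyl on a double-bonded chain carbon bound to a double-bonded ring carbon. Among the compounds with values here, no measured step covers that swap; the most that can be said is that the two analogues without bromine, compounds 1 and 3, sit lower than compound 2 in this assay. Compound 4 is therefore expected to show a step of a 3.5-fold lower number from compound 2 to compound 4 (0.54 log units; beyond the scatter), toward a lower number. The estimate for compound 4 is 1500 nM, within 600 nM to 4000 nM.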

Compound 4, half-maximal inhibitory concentration: 4600 nM
Compound 4: middle estimate off by 3.1-fold (0.49 log units), on the low side; measured number above the stated range.
By their numbers in this assay, from the lowest: compound 3; then compounds 1, 4 and 2 (each within the scatter of the next, the first and the last beyond it).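

In this assay the swap gives a 1.1-fold lower number from compound 2 to compound 4 (0.05 log units; within the scatter) and leaves 4-hydroxy-3-methoxyphenyl and 3-bromophenyl not told apart at this place. A ring without bromine is thus not enough to set compound 4 apart from compound 2, and a ring with a hydrogen-bond donor reads the same here as a ring with none. Nothing on hand gives a reason for this result.

Open, going by these compounds, is whether an amine in place of the hydroxyl group of compound 4 would read any differently in this assay at this place. Also open, on these data alone, is whether the hydroxyl or the methoxy group of that ring would read the same if either stood alone.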